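Three oxadiazole-linked compounds tolerated by macrophages; a fourth awaits

The source may report more compounds than this note shows. Statements on the series, on what has been measured and on what is new or still open speak of the compounds shown alone.

Compound 1 `Fc1cccc(Cc2nnc(Cn3nnc4ccccc43)o2)c1` and compound 2 `COc1cccc(Cc2nnc(Cn3nnc4ccccc43)o2)c1` share a core and differ only in one group: methoxy in place of fluoro on an aromatic carbon. In an ADME assay on cells (Macrophage, Homo sapiens) for inhibition (a lower number here means that less compound is tolerated, a higher number that more compound is tolerated), compound 1 gives > 100000 nM, which is a limit of the assay rather than a number. Compound 2 likewise gives > 100000 nM, again a limit. The change is therefore a step that the two limits leave unreadable from compound 1 to compound 2. Compound 3 `Fc1cccc(-c2nnc(Cn3nnc4ccccc43)o2)c1` has a different core; the difference between the two cores is not broken down here. Compound 3 gives > 100000 nM, also a limit. Compound 4 `COc1cccc(-c2nnc(Cn3nnc4ccccc43)o2)c1` has not yet been measured and differs from compound 3 by the same change: methoxy in place of fluoro on an aromatic carbon. Because (the limit of > 100000 nM in this assay, at which 3 of the 3 values shown sit), the step from compound 3 to compound 4 is expected to stay unreadable, a step that the limit leaves unreadable from compound 3 to compound 4. Compound 4 is estimated at 150000 nM, most likely reported as a limit.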

Compound 4, half-maximal cytotoxic concentration: > 100000 nM
Compound 4: no number, only a limit (the forecaster's own chance of this, stated with the estimate: 85%); the middle value does not contradict the limit.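

No step can be read between compound 3 and compound 4, because both values are limits rather than numbers: the limit of > 100000 nM in this assay, at which 4 of the 4 values shown sit.

Left open is the concentration at which any of the four compounds stops being tolerated in this assay.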